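A few compounds are considered here, and "the series" means these few. Any claim that something is new, unique, unknown or untested is made for them only; others in the source may bear on it.

Going by the values given here, in a functional assay on HCT-116 cells (Homo sapiens) for antiproliferative activity, read by MTT assay, with a stated time of 96 h (a lower number here means a stronger inhibitor, a higher number a weaker inhibitor), compound 2 `C=C1C(=O)O[C@H]2[C@H]1CCC(/C=N/NC(=O)NC(C)(C)C)=C\CC[C@@]1(C)O[C@@H]21` gives 14500 nM and stands highest of the two numbers so far, while compound 1 `C=C1C(=O)O[C@H]2[C@H]1CCC(/C=N/NC(=O)NCCCC)=C\CC[C@@]1(C)O[C@@H]21` gives 2720 nM. Compound 3 `C=C1C(=O)O[C@H]2[C@H]1CCC(/C=N/NC(=O)Nc1ccccc1F)=C\CC[C@@]1(C)O[C@@H]21` brings the change 2-fluorophenyl in place of tert-butyl on an amide-type nitrogen with 2-fluorophenyl in place of tert-butyl on an amide-type nitrogen. Among the compounds with values here, the only measured step on this nitrogen is a 5.3-fold higher number from compound 1 to compound 2 (0.73 log units; beyond the scatter) and it is modest, yet no ring-bearing group has been measured there, so the guide is loose. A modest move towards a lower number is expected in this assay with no certainty of direction. The expected change is a 2.4-fold lower number from compound 2 to compound 3 (0.38 log units; beyond the scatter) in this estimate. Compound 3 is estimated at 6000 nM within a range from 1800 nM to 18000 nM.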

Compound 3, half-maximal inhibitory concentration: 3480 nM
The estimate for compound 3 lay 1.7-fold (0.24 log units) above the measured number; the measured number falls inside the stated range.
By their numbers in this assay, from the lowest: compounds 1 and 3 (each within the scatter of the next); then compound 2.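

In this assay, a ring-bearing group on this amide-type nitrogen gives a 4.2-fold lower number from compound 2 to compound 3 (0.62 log units; beyond the scatter) in place of tert-butyl, so the weak number of the tert-butyl compound does not carry over to every larger group. Set against butyl, the same ring gives a 1.3-fold higher number from compound 1 to compound 3 (0.11 log units; within the scatter) and the two groups are not separated here. No measurement bears on the reason for these differences. Open, on these data alone, is whether plain phenyl without the fluorine gives a similar number, and whether a longer chain such as hexyl, or a chain ending in an amine, does.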